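Removing the chloro group on the acetyl core of compound 2

This account rests on a few compounds, and the source may have more. Where it says the series, first, only, none or still open, it means among the compounds named here.

Measured compounds in an assay on isolated protein for inhibition of Nitric oxide synthase, inducible (Homo sapiens), read by scintillation counting, with a stated time of 30 min, tested at 50 uM; on this read-out higher numbers stand for more inhibition at the one concentration tested (going by the name of the read-out) and lower numbers for less inhibition:
compound 1 `CC1(C)SC(c2ccccc2N)=NN1C(=O)c1ccccc1`: 39.8%
compound 2 `CC(=O)N1N=C(c2cc(Cl)ccc2N)SC1(C)C`: 72.8%
compound 3 `CC1(C)SC(c2cc(Cl)ccc2N)=NN1C(=O)c1ccccc1`: 20.8%

Of the compounds shown here, three have been measured in this assay so far. Compound 2 stands highest of the three, with compound 1 nearest and compound 3 furthest; both gaps are beyond the scatter. Two measured steps connect them. From compound 3 to compound 2 the change is methyl in place of phenyl on a carbonyl carbon, and this step is a number 52 percentage points lower from compound 2 to compound 3 (beyond the scatter) when read in the other direction. From compound 3 to compound 1 the change is hydrogen in place of chloro on an aromatic carbon, and the step is a number 19 percentage points higher from compound 3 to compound 1 (beyond the scatter).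

Compound 4 `CC(=O)N1N=C(c2ccccc2N)SC1(C)C` has not yet been measured. It differs from compound 2 by hydrogen in place of chloro on an aromatic carbon, which is the same change as that from compound 3 to compound 1: the place lines match word for word, and the change has occurred twice among the compounds shown. The two cores differ by methyl in place of phenyl on a carbonyl carbon, so the precedent comes from the benzoyl core while compound 4 carries the acetyl core.

Resting on that single precedent, the step from compound 2 to compound 4 is expected to be a number 7.2 percentage points higher from compound 2 to compound 4 (within the scatter), a rise of a similar kind to the step from compound 3 to compound 1, tempered because compound 2 already sits at 72.8% and the core is not the same. Compound 4 is therefore estimated at 80%, with a range from 58% to 94%.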

Compound 4, a percentage reported as inhibition, at one concentration (the size of the read-out at that concentration, not a potency): 22.9%
Compound 4: middle estimate off by 57.1 percentage points, on the high side; the measured number lies below the stated range.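

In this assay, hydrogen in place of chloro on an aromatic carbon gives a number 49.9 percentage points lower from compound 2 to compound 4 (beyond the scatter), so this change does not carry from the benzoyl core to the acetyl core, in either direction or size: the same change on two cores in this assay, a number 19 percentage points higher (beyond the scatter) from compound 3 to compound 1 and a number 49.9 percentage points lower (beyond the scatter) from compound 2 to compound 4, 68.9 percentage points apart, beyond the scatter of two such steps Methyl in place of phenyl on a carbonyl carbon gives a number 16.9 percentage points lower from compound 1 to compound 4 (beyond the scatter), and this change also depends on what else the compound carries: the same change on two cores in this assay, a number 52 percentage points lower (beyond the scatter) from compound 2 to compound 3 and a number 16.9 percentage points higher (beyond the scatter) from compound 4 to compound 1, 68.9 percentage points apart, beyond the scatter of two such steps The four compounds form one closed square, so these two comparisons are the same finding seen from two sides, not independent results; it shows that the chloro group and the group on the carbonyl do not act separately on this read-out, but it rests on single readings at one concentration and does not show why they interact or how potency would compare.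

The compounds shown leave open whether this dependence extends to other groups at the same aromatic carbon, such as fluoro, bromo or methoxy, or to other groups on the carbonyl, such as ethyl or a longer chain. On these data alone, they also hold the amino group and the two methyl groups constant throughout, so the effect of replacing either, for example with a hydroxyl group or an ethyl group, remains unknown.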